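The source may report more compounds than this note shows. Statements on the series, on what has been measured and on what is new or still open speak of the compounds shown alone.

Measured compounds:
compound 1, `Cc1cc(N2CCC(N)CC2)c(S(C)(=O)=O)cc1C(=O)N=C(N)N`, in a functional assay for inhibition of sodium/hydrogen exchanger (Oryctolagus cuniculus) (on this read-out higher numbers stand for weaker inhibition and lower numbers for stronger inhibition), gives 9.8 nM
compound 2, `COc1ccc(C(=O)N=C(N)N)cc1S(C)(=O)=O`, in this assay gives 270 nM
compound 3, `Cc1ccc(C(=O)N=C(N)N)cc1S(C)(=O)=O`, in this assay gives 210 nM

Among these three numbers compound 3 stands second highest. Its nearest neighbour is compound 2, and the step between them, a 1.3-fold lower number from compound 2 to compound 3 (0.11 log units; within the scatter), is too small to count as a real difference. Its furthest neighbour is compound 1, whose number is far lower, well beyond the scatter.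

The next compound, compound 4, `CS(=O)(=O)c1cc(C(=O)N=C(N)N)ccc1N1CCC(N)CC1`, differs from compound 3 in one place: 4-aminopiperidin-1-yl in place of methyl on an aromatic carbon.

Going by the values given here, only one measured step is available, a 1.3-fold lower number from compound 2 to compound 3 (0.11 log units; within the scatter), and it exchanges two small groups that have nothing to do with the entering group, so it offers no guide here. What does bear on the change is compound 1, which already carries a 4-aminopiperidin-1-yl group on its core, differs from compound 4 by a single methyl only, and gives the lowest number of the set. On that basis a large drop in the number is expected for compound 4, a 14-fold lower number from compound 3 to compound 4 (1.15 log units; beyond the scatter), with the estimate resting mainly on the value of compound 1 in this assay, 9.8 nM.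

Compound 4 is therefore estimated at 15 nM, most likely between 4 nM and 60 nM.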

Compound 4, half-maximal inhibitory concentration: 160 nM
Compound 4: middle estimate off by 11-fold (1.03 log units), on the low side; measured number above the stated range.
By their numbers in this assay, from the lowest: compound 1; then compounds 4, 3 and 2 (each within the scatter of the next).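

In this assay, 4-aminopiperidin-1-yl on this aromatic carbon, ortho to the methylsulfonyl group, gives a 1.3-fold lower number from compound 3 to compound 4 (0.12 log units; within the scatter) when it replaces methyl and a 1.7-fold lower number from compound 2 to compound 4 (0.23 log units; within the scatter) when it replaces methoxy. Both steps lie within the scatter, so on the core of compound 4 this much larger group cannot be told apart from either small group. Going by these compounds alone, the large step appears elsewhere, in the single change of hydrogen in place of methyl on an aromatic carbon, a 16-fold higher number from compound 1 to compound 4 (1.21 log units; beyond the scatter), so the low number of compound 1 needs both that methyl and 4-aminopiperidin-1-yl to be read correctly, and the group alone does not carry it. No measurement at hand explains why the methyl matters so much here.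

As far as these compounds go, whether that same methyl would lower the number with methoxy at this position, or only with 4-aminopiperidin-1-yl, remains open. So does the behaviour of other groups at this position in the presence of the methyl, such as dimethylamino, a piperidine without its amine, or a piperazine.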